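The compounds below may be only part of what the source reports. "The series", "measured", "known", "first", "only" and "open" are said of these compounds alone.

The measured compounds in a functional assay on HCT-116 cells (Homo sapiens) for inhibition, read by sulforhodamine B assay, with a stated time of 48 h, tested at 50 uM; a higher number here means more inhibition of growth at the concentration tested, a lower number less inhibition of growth:

Compound 1, `O=C1C(=O)N(CCCCn2cc(COc3cc(=O)oc4ccccc34)nn2)c2ccccc21`, gives 72%.
Compound 2, `O=C1C(=O)N(CCCCCn2cc(COc3cc(=O)oc4ccccc34)nn2)c2ccc(F)cc21`, gives 59%.
Compound 3, `O=C1C(=O)N(CCCCCn2cc(COc3cc(=O)oc4ccccc34)nn2)c2ccccc21`, gives 65%.

Compound 1 and compound 3 carry the same end groups but are joined by different chains; the difference between the two cores is not broken down here. Their numbers in this assay lie within the usual scatter of each other, so no order between them can be claimed. Compound 2 differs from compound 3 by a single change, (fluoro in place of hydrogen on an aromatic carbon), and the step is a number 6 percentage points lower from compound 3 to compound 2 (within the scatter).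

Compound 4, `O=C1C(=O)N(CCCCn2cc(COc3cc(=O)oc4ccccc34)nn2)c2ccc(F)cc21`, has not yet been measured. It differs from compound 1 by fluoro in place of hydrogen on an aromatic carbon, which is the same change, made on the core of compound 1 rather than on that of compound 3. For the measured compounds named here, the expectation for compound 4 therefore rests on the value of compound 1 and on the one measured example of this change. A similarly small step is expected for compound 4, estimated as a number 6 percentage points lower from compound 1 to compound 4 (within the scatter), because the earlier step of a number 6 percentage points lower from compound 3 to compound 2 (within the scatter) was within the scatter. Compound 4 is thus estimated at 66% in this assay, with a likely range from 54% to 78%. Since this rests on a single measured example, the range is kept wide.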

Compound 4, percent growth inhibition at one concentration: 67%
Estimate against measurement, compound 4: 1 percentage points below; the range from low to high includes it.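

In this assay, the step for fluoro in place of hydrogen on an aromatic carbon, on the core of compound 1, is a number 5 percentage points lower from compound 1 to compound 4 (within the scatter). Set beside the step seen on the other core, the new step agrees with it, and the change carries over between these two cores with much the same small size: the same change on two cores in this assay, a number 6 percentage points lower (within the scatter) from compound 3 to compound 2 and a number 5 percentage points lower (within the scatter) from compound 1 to compound 4, 1 percentage points apart, within the scatter of two such steps What this does not show is that fluoro has any real effect in this series, since each step lies within the scatter and a small true drop cannot be told apart from no change at all; nor does agreement between two closely related cores, which differ only in the chain joining the same end groups, establish that the step would hold on a core of a different kind.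

The compounds shown carry only hydrogen or fluoro at this place, so it stays open what a chloro group, a methoxy group or an amine would do there, and whether fluoro would behave alike elsewhere on the ring. As far as these compounds go, it also stays open whether the step would remain this small with a longer chain, or at a concentration other than the single one tested.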